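Dropping the Methyl: From Compound 1 to Compound 3

The source may hold more compounds than are shown below. What is called first, only, known or untested is meant among the compounds shown, and "the series" means these compounds.

compound 1, `CCCSc1nc(N/N=C/c2ccc(C)cc2)c2nnn(Cc3ccccc3)c2n1`: > 64000 nM
compound 2, `C#CCSc1nc(N/N=C/c2c(O)ccc3ccccc23)c2nnn(Cc3ccccc3)c2n1`: 8970 nM

Of the compounds shown here, two have been tested in a functional assay on MCF7 cells (Homo sapiens) for antiproliferative activity, read by MTT assay, with a stated time of 72 h; a higher number here means a weaker inhibitor, a lower number a stronger inhibitor. For compound 1 the result is only a limit of the assay, > 64000 nM, and not a number. Compound 2 gives 8970 nM in this assay. Compound 1 therefore stands at the edge of what this assay reports, as the limit of > 64000 nM in this assay, at which 1 of the 2 values shown sits, shows, and only compound 2 has a measured value.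

Compound 3, `CCCSc1nc(N/N=C/c2ccccc2)c2nnn(Cc3ccccc3)c2n1`, has not yet been tested. It differs from compound 1 in one place: hydrogen in place of methyl on an aromatic carbon.

Going by the values given here, no measured pair differing in a single place exists here, so the size of this step is not known from the data. The author expects the step from compound 1 to compound 3 to be small, without a clear direction beyond the scatter of this assay, and expects that compound 3 will again most likely sit at the limit rather than give a number, which is what a number no higher from compound 1 to compound 3 (the limit leaves the size open) expresses. For compound 3 the expected value in this assay is 64000 nM, with a range from 20000 nM to 200000 nM.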

Compound 3, half-maximal inhibitory concentration: > 64000 nM
Compound 3 was reported as a limit; the forecaster's own chance of this, stated with the estimate: 70%; the middle value lies on the limit itself.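

Compound 3, like compound 1, is reported in this assay only as a limit of the assay and not as a number, so no step can be read between compound 1 and compound 3. The compounds shown leave open what the change from 4-methylphenyl to phenyl does to activity, and the result they share is this: the limit of > 64000 nM in this assay, at which 2 of the 3 values shown sit.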